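The source may report more compounds than this note shows. Statements on the series, on what has been measured and on what is new or still open speak of the compounds shown alone.

Compound 1, `O=C1CCCC/C1=C\c1ccccc1[N+](=O)[O-]`, compound 2, `O=C1/C(=C/c2ccc(F)cc2)CCC/C1=C\c1cccc([N+](=O)[O-])c1`, and compound 3, `O=C1/C(=C/c2ccc(Cl)cc2)CCC/C1=C\c1ccc([N+](=O)[O-])cc1`, were examined in a functional assay on MOLT-4 cells (Homo sapiens) for cytotoxicity, with a stated time of 72 h; on this read-out lower numbers stand for stronger inhibition and higher numbers for weaker inhibition. Compound 1 gives 33300 nM in this assay, compound 3 gives 9120 nM, and compound 2 gives 5120 nM. Compound 2 thus shows the lowest number of the three in this assay: the gap to compound 3 lies within the usual scatter of repeated measurements, while the gap to compound 1 lies beyond it.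

Compound 4, `CN(C)c1ccc(/C=C2\CCC/C(=C\c3cccc([N+](=O)[O-])c3)C2=O)cc1`, is the compound that has not yet been measured. It differs from compound 2 in one place, on an aromatic carbon of a six-membered aromatic ring of carbon only, para to a large group: dimethylamino in place of fluoro on an aromatic carbon, so that 4-fluorophenyl becomes 4-(dimethylamino)phenyl. Going by the values given here, no pair of measured compounds here shows this change, so there is no comparable step from which its size can be read off. The expectation is a modest step in this assay from compound 2 to compound 4 of a 1.7-fold lower number from compound 2 to compound 4 (0.23 log units; within the scatter), towards a somewhat lower number but not clearly beyond the scatter. Compound 4 is therefore estimated at 3000 nM in this assay, with a range from 800 nM to 12000 nM.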

Compound 4, half-maximal inhibitory concentration: 10900 nM
Beside the measured number, compound 4's estimate is 3.6-fold (0.56 log units) below it, within the range that was stated.
By their numbers in this assay, from the lowest: compounds 2, 3 and 4 (each within the scatter of the next, the first and the last beyond it); then compound 1.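

Dimethylamino in place of fluoro on this aromatic carbon, para to a large group, gives in this assay a 2.1-fold higher number from compound 2 to compound 4 (0.33 log units; beyond the scatter), a modest step that lies just beyond the scatter. Going by these compounds alone, the earlier compounds differ from one another in more than one place, so this is the first direct reading of any single change. It shows that this position responds to the choice of group, and that the 4-(dimethylamino)phenyl compound keeps measurable cytotoxicity with only a modest loss from the 4-fluorophenyl compound. Nothing available here accounts for the size or direction of this step.

The compounds shown leave open whether a simple amino group or a methoxy group at this same place would follow dimethylamino or stay closer to fluoro. They also leave open whether the same exchange gives a similar step in a compound carrying its nitro group elsewhere.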